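Working notes: aryl methoxy variation in a seizure-model series

The source may hold more compounds than are shown below. What is called first, only, known or untested is meant among the compounds shown, and "the series" means these compounds.

Measured so far:
compound 1 `CN1C(=O)NC2(CC2(C)C)C1=O`: 90%
compound 2 `CC1(C)CC12NC(=O)N(c1ccccc1)C2=O`: 80%

In a functional assay on the whole organism for inhibition, with Mus musculus as the target, in the maximal electroshock model, at a dose of 30 mg/kg by the oral route (a higher number here means a stronger effect of the compound at the dose given, a lower number a weaker effect), compound 1 gives 90% and compound 2 gives 80%. Compound 2 has the lower of the two numbers, but the gap to compound 1 is within the usual scatter of this assay, so the two values cannot be ordered.

Compound 3 `COc1ccc(N2C(=O)NC3(CC3(C)C)C2=O)cc1` is not yet measured. It differs from compound 2 by methoxy in place of hydrogen on an aromatic carbon.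

Going by the values given here, no pair of measured compounds differs in a single place, so there is no step on which to base the size of the change from compound 2 to compound 3. With nothing against it, for compound 3 the step is expected to be a number 5 percentage points lower from compound 2 to compound 3 (within the scatter), which is estimated to be no larger than the scatter and in no firm direction. For compound 3 the estimate in this assay is 75%, from 50% to 95%.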

Compound 3, a percentage reported as inhibition, in the whole organism at one dose (the size of the read-out at that dose, not a potency): 60%
For compound 3 the middle estimate is 15 percentage points above the measured one, within the range that was stated.
By their numbers in this assay, from the lowest: compound 3; then compounds 2 and 1 (each within the scatter of the next).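

In this assay, going by these compounds alone, methoxy in place of hydrogen on an aromatic carbon, para to a large group, gives a number 20 percentage points lower from compound 2 to compound 3 (beyond the scatter) as the first step that can be read at a single place. The six-membered aromatic ring of compound 2 therefore does not accept every change at this position without a loss of effect at the dose given, although this is a size of effect at one dose and not a potency. No measurement at hand bears on the reason for this step.

On these data alone, it remains open whether the loss belongs to methoxy itself or to any group at this position. Fluorine, a hydroxyl group or a longer chain such as ethoxy at the same place would help separate these readings, as would methoxy at another place on the ring.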